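Compound 1 to compound 3: one group exchanged

The source may report more compounds than this note shows. Statements on the series, on what has been measured and on what is new or still open speak of the compounds shown alone.

Compound 1 `CCN(CC)CCn1c(N)c(-c2nc3ccccc3n2C)c2nc(C#N)c(C#N)nc21` gives > 50000 nM (a limit)
Compound 2 `CCN(CC)CCCn1c(N)c(-c2nc3ccccc3n2C)c2nc(C#N)c(C#N)nc21` gives 6750 nM

In a functional assay on cells (Homo sapiens) for antiproliferative activity, read by MTT assay, with a stated time of 48 h (on this read-out higher numbers stand for weaker inhibition and lower numbers for stronger inhibition), compound 1 gives > 50000 nM, which is a limit of the assay and not a number. Compound 3 `CCN(CC)CCn1c(N)c(-c2nc3cc(Cl)ccc3[nH]2)c2nc(C#N)c(C#N)nc21` keeps the 2-(diethylamino)ethyl group of compound 1 and changes on an aromatic carbon: 5-chloro-1H-benzimidazol-2-yl in place of 1-methyl-1H-benzimidazol-2-yl on an aromatic carbon. Going by the values given here, the only measured step, an at least 7.4-fold lower number from compound 1 to compound 2 (0.86 log units; beyond the scatter), lies in the chain and not at this place, so it bears on the change only indirectly. Among the compounds with values here, with compound 2 at 6750 nM as the only number available, a modest move toward lower numbers is expected. Compound 3 may still stay at the limit of the assay. The expected step is an at least 3.3-fold lower number from compound 1 to compound 3 (0.52 log units; beyond the scatter). For compound 3 the estimate is 15000 nM, with an expected range of 3000 nM to 60000 nM.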

Compound 3, half-maximal inhibitory concentration: > 50000 nM
Compound 3: no number, only a limit; the forecaster's own chance of this, stated with the estimate: 35%; at least 3.3-fold (0.52 log units) between middle value and limit.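

Going by these compounds alone, compound 3, like compound 1, gives only a limit of the assay and not a number, so no step between them can be read: the limit of > 50000 nM in this assay, at which 2 of the 3 values shown sit.

The compounds shown leave open whether 5-chloro-1H-benzimidazol-2-yl in place of 1-methyl-1H-benzimidazol-2-yl changes the number at all, with the chain of compound 1 or that of compound 2.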